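Fluoro to chloro on a sulfonyl aryl ring

A few compounds are considered here, and "the series" means these few. Any claim that something is new, unique, unknown or untested is made for them only; others in the source may bear on it.

Values in a functional assay on HeLa cells (Homo sapiens) for cytotoxicity, read by sulforhodamine B assay (on this read-out lower numbers stand for stronger inhibition and higher numbers for weaker inhibition), stand as follows
compound 1 `Cc1ccccc1S(=O)(=O)NC(C1=CC(=O)c2c(O)ccc(O)c2C1=O)C(C)C` gives 790 nM
compound 2 `COc1ccc(S(=O)(=O)NC(C2=CC(=O)c3c(O)ccc(O)c3C2=O)C(C)C)cc1` gives 8950 nM
compound 3 `CC(C)C(NS(=O)(=O)c1ccc(F)cc1)C1=CC(=O)c2c(O)ccc(O)c2C1=O` gives 6650 nM

Compound 3 sits at the high end of these numbers, level with compound 2 and well above compound 1 (an 8.4-fold higher number from compound 1 to compound 3 (0.93 log units; beyond the scatter)). Compound 4 `CC(C)C(NS(=O)(=O)c1ccc(Cl)cc1)C1=CC(=O)c2c(O)ccc(O)c2C1=O` carries chloro in place of fluoro on an aromatic carbon, para to a large group (chloro in place of fluoro on an aromatic carbon). The closest measured swap, fluoro in place of methoxy on an aromatic carbon, gave only a small shift (a 1.3-fold lower number from compound 2 to compound 3 (0.13 log units; within the scatter)). The larger steps (an 11-fold higher number from compound 1 to compound 2 (1.05 log units; beyond the scatter)) and (an 8.4-fold higher number from compound 1 to compound 3 (0.93 log units; beyond the scatter)) exchange the whole aryl group of compound 1, so they bear less on this change. In this assay no step beyond the scatter is therefore expected. The expected step is small (a 1.2-fold lower number from compound 3 to compound 4 (0.08 log units; within the scatter)). Compound 4 is estimated at 5500 nM with an expected range from 2200 nM to 12000 nM for repeated measurements.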

Compound 4, half-maximal inhibitory concentration: 8650 nM
Beside the measured number, compound 4's estimate is 1.6-fold (0.20 log units) below it; the range from low to high includes it.
By their numbers in this assay, from the lowest: compound 1; then compounds 3, 4 and 2 (each within the scatter of the next).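

In this assay, chloro in place of fluoro on this aromatic carbon, para to a large group, stays within the scatter (a 1.3-fold higher number from compound 3 to compound 4 (0.11 log units; within the scatter)), and chloro in place of methoxy does too (a 1.0-fold lower number from compound 2 to compound 4 (0.01 log units; within the scatter)), so all three groups at this place now read alike. The 2-methylphenyl of compound 1 stands apart from the 4-chlorophenyl as well (an 11-fold higher number from compound 1 to compound 4 (1.04 log units; beyond the scatter)), as it did from the other two aryl groups. No evidence at hand bears on this result. The compounds shown leave open whether the gap to compound 1 goes with its methyl group or with where that group sits, and whether an amine or a carboxylic acid at this place would read like chloro.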